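The source may hold more compounds than are shown below. What is called first, only, known or untested is meant among the compounds shown, and "the series" means these compounds.

Measured compounds in the series:

compound 1, `CN(C)CCN1CCN(CC(=O)Nc2ccc(-c3nc4ccccc4o3)cc2)CC1` — 16300 nM
compound 2, `CN(C)CCN1CCN(CC(=O)Nc2ccc(-c3nc4cc(F)ccc4o3)cc2)CC1` — 18800 nM
compound 3, `Cc1cc(-c2nc3ccccc3o2)ccc1NC(=O)CN1CCN(CCCN(C)C)CC1` — 2160 nM

All three have been run in a functional assay on HepG2 cells (Homo sapiens) for cytotoxicity, read by MTT assay, with a stated time of 24 h; a higher number here means a weaker inhibitor, a lower number a stronger inhibitor. Compound 1 gives 16300 nM. Compound 2 differs from it by one change, (fluoro in place of hydrogen on an aromatic carbon), and the step in this assay is a 1.2-fold higher number from compound 1 to compound 2 (0.06 log units; within the scatter), so the two numbers cannot be told apart. Compound 3 carries a different core; how its core differs from that of compound 1 is not broken down here. Compound 3 gives 2160 nM, the lowest of the three numbers, and its gaps to compound 1 and to compound 2 are both beyond the scatter, so within this set compound 3 is the strongest inhibitor.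

Compound 4, `Cc1cc(-c2nc3cc(F)ccc3o2)ccc1NC(=O)CN1CCN(CCCN(C)C)CC1`, has not yet been measured in this assay. Among the compounds with values here, it differs from compound 3 by fluoro in place of hydrogen on an aromatic carbon, which is the same change as the one from compound 1 to compound 2, made on the same place and read the same way one bond further out. Since that change gave a 1.2-fold higher number from compound 1 to compound 2 (0.06 log units; within the scatter), the step from compound 3 to compound 4 is expected to be small as well, about a 1.2-fold higher number from compound 3 to compound 4 (0.06 log units; within the scatter). On that basis compound 4 is estimated at 2500 nM in this assay, with a range from 1200 nM to 5500 nM, the uncertainty resting on a single prior instance of the change.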

Compound 4, half-maximal inhibitory concentration: 7150 nM
Estimate against measurement, compound 4: 2.9-fold (0.46 log units) below; measured number outside the range, above it.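

In this assay, the change from 1,3-benzoxazol-2-yl to 5-fluoro-1,3-benzoxazol-2-yl gives a 3.3-fold higher number from compound 3 to compound 4 (0.52 log units; beyond the scatter), so on this second core the fluoro costs measurable potency, whereas on the first core it produced no readable shift. Within the data shown here, the step therefore does not carry over at a constant size between these cores, and a value read from one core is a poor guide to the other: the same change on two cores in this assay, a 1.2-fold higher number (0.06 log units; within the scatter) from compound 1 to compound 2 and a 3.3-fold higher number (0.52 log units; beyond the scatter) from compound 3 to compound 4, 2.9-fold (0.46 log units) apart, beyond the scatter of two such steps What this does not show is which feature of the cores sets the size of the step, since the cores differ from each other in more than the fluoro position and each core supplies only a single pair, so no general rule for the change follows from these compounds.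

Open, on these data alone, is whether a chloro or methoxy group in place of the same hydrogen would also give a larger step on the core of compound 3 than on the core of compound 1, or whether this gap belongs to fluoro alone. Also open, as far as these compounds go, is whether a fluoro on another aromatic carbon of the six-membered ring would give a step of similar size on either core.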